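Removing the nitro group: compound 3 to compound 4

The source may report more compounds than this note shows. Statements on the series, on what has been measured and on what is new or still open speak of the compounds shown alone.

Three ureas on the shared core have numbers in a functional assay on OVCAR-3 cells (Homo sapiens) for inhibition; a higher number here means a weaker inhibitor, a lower number a stronger inhibitor. Compound 1 `N#CC1CN1C(=O)Nc1ccc(F)cc1` gives 5900 nM. Compound 2 `CCOC(=O)c1ccc(NC(=O)N2CC2C#N)cc1` gives 7700 nM. Compound 3 `N#CC1CN1C(=O)Nc1ccc([N+](=O)[O-])cc1` gives 6500 nM. Compound 3 sits alongside the other two, since a 1.1-fold higher number from compound 1 to compound 3 (0.04 log units; within the scatter) and a 1.2-fold lower number from compound 2 to compound 3 (0.07 log units; within the scatter) both fall inside the scatter, and the remaining step, a 1.3-fold higher number from compound 1 to compound 2 (0.12 log units; within the scatter), does the same; the three numbers cannot be separated.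

Compound 4 `N#CC1CN1C(=O)Nc1ccccc1` has not been measured. It differs from compound 3 by hydrogen in place of nitro on an aromatic carbon. Among the compounds with values here, no measured step removes a substituent from that aromatic carbon outright, so the evidence is indirect. The three swaps at this carbon among fluoro, ethoxycarbonyl and nitro each stayed within the scatter, which suggests that what stands on this carbon does not move the number in this assay across the compounds seen so far. For compound 4 the expected step is therefore no change at the digits printed from compound 3 to compound 4 (within the scatter), with no movement beyond the scatter. The estimated value for compound 4 is 6500 nM, in a range from 3000 nM to 14000 nM.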

Compound 4, half-maximal inhibitory concentration: 6800 nM
For compound 4 the middle estimate is 1.0-fold (0.02 log units) below the measured one; low and high end bracket the measured number.
By their numbers in this assay, from the lowest: compounds 1, 3, 4 and 2 (each within the scatter of the next).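

With hydrogen on this aromatic carbon, the series in this assay now has direct steps from each substituted urea to the unsubstituted one (a 1.0-fold higher number from compound 3 to compound 4 (0.02 log units; within the scatter)) (a 1.1-fold lower number from compound 2 to compound 4 (0.05 log units; within the scatter)) (a 1.2-fold higher number from compound 1 to compound 4 (0.06 log units; within the scatter)). The earlier compounds shown here only exchanged one group for another, whereas these steps show that nitro, ethoxycarbonyl and fluoro cannot be separated from the absence of any heavy atom at this carbon, and none of the four compounds goes against this. No supporting data bear on why these numbers cannot be separated.

As far as these compounds go, it remains open whether an amine, a carboxylic acid or a longer alkyl chain on this carbon would give a step beyond the scatter. From the compounds shown here alone, the nitrile and the rest of the shared core are the same in all four compounds, so the effect of a change there also remains open.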